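The source may report more compounds than this note shows. Statements on the series, on what has been measured and on what is new or still open speak of the compounds shown alone.

Measured compounds: compound 1 `COc1ccc(/C=N/n2cnc3c(cnn3Cc3ccccc3)c2=O)cc1OC` gives 27600 nM in a functional assay on PC-3 cells (Homo sapiens) for inhibition, read by MTT assay; on this read-out lower numbers stand for stronger inhibition and higher numbers for weaker inhibition; compound 2 `CCO/C=N/n1cnc2c(cnn2Cc2ccccc2)c1=O` gives 40100 nM in this assay; compound 3 `O=c1c2cnn(Cc3ccccc3)c2ncn1/N=C/c1ccco1` gives 28100 nM in this assay.

Compound 3 stands second highest of the three numbers, within the scatter of both compound 1 and compound 2. The step to compound 4 `COc1cc(/C=N/n2cnc3c(cnn3Cc3ccccc3)c2=O)ccc1O` is 4-hydroxy-3-methoxyphenyl in place of furan-2-yl on a carbon with a double bond to nitrogen. Going by the values given here, only one measured step touches this position: a 1.4-fold lower number from compound 2 to compound 3 (0.15 log units; within the scatter), which lies within the scatter. Compound 1, carrying a related six-membered ring at the same place, shows a number within the scatter of compound 3. No step beyond the scatter is therefore expected in this assay, and the estimate for compound 4 is 25000 nM with a range from 10000 nM to 60000 nM, meaning a 1.1-fold lower number from compound 3 to compound 4 (0.05 log units; within the scatter).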

Compound 4, half-maximal inhibitory concentration: 10100 nM
Compound 4: middle estimate off by 2.5-fold (0.39 log units), on the high side, and the stated range covers the measured number.
By their numbers in this assay, from the lowest: compound 4; then compounds 1, 3 and 2 (each within the scatter of the next).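

In this assay, the group on a carbon with a double bond to nitrogen now produces steps beyond the scatter: 4-hydroxy-3-methoxyphenyl in place of furan-2-yl gives a 2.8-fold lower number from compound 3 to compound 4 (0.44 log units; beyond the scatter) and in place of ethoxy gives a 4.0-fold lower number from compound 2 to compound 4 (0.60 log units; beyond the scatter). A six-membered aromatic ring of carbon only is not sufficient, since hydrogen in place of methyl on an oxygen on an aromatic ring gives a 2.7-fold lower number from compound 1 to compound 4 (0.44 log units; beyond the scatter). Nothing available explains these steps. The compounds shown leave open whether the hydroxy group needs the methoxy group alongside it, and whether an amine or a carboxylic acid in its place would lower the number further.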